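A few compounds are considered here, and "the series" means these few. Any claim that something is new, unique, unknown or untested is made for them only; others in the source may bear on it.

Measured compounds:
compound 1 `CCCCCCCCCCCCCCCCCCc1c(O)cc(O)c(C(C)=O)c1O` – 31000 nM
compound 2 `CCCCCCCCCCCCCCCCCCOc1cc(O)cc(O)c1C(C)=O` – > 100000 nM
compound 3 `CC(=O)c1c(O)c(CC=C(C)C)c(O)c(CC=C(C)C)c1O` – > 100000 nM

In a functional assay on HL-60 cells (Homo sapiens) for cytotoxicity, read by XTT assay, with a stated time of 72 h (on this read-out lower numbers stand for stronger inhibition and higher numbers for weaker inhibition), compound 1 gives 31000 nM. For compound 2 this assay reports only a limit, > 100000 nM. For compound 3 this assay likewise reports only a limit, > 100000 nM, and no number; compound 3 thus stands at the limit of > 100000 nM in this assay, at which 2 of the 3 values shown sit, so no ranking of it against the others can be drawn.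

Compound 4 `CC(=O)c1c(O)cc(O)c(CC=C(C)C)c1O` differs from compound 3 by hydrogen in place of 3-methylbut-2-en-1-yl on an aromatic carbon. With both neighbours of compound 3 at or near the weak end of the shown values, the step from compound 3 to compound 4 is expected to be small, with no direction beyond the scatter claimed; the expected step is a step that the limit leaves unreadable from compound 3 to compound 4. Compound 4 is accordingly estimated at 120000 nM, within 40000 nM to 400000 nM.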

Compound 4, half-maximal inhibitory concentration: 32000 nM
Compound 4: the middle estimate sits 3.8-fold (0.57 log units) above what was measured, outside the stated range (below it).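

In this assay, hydrogen in place of 3-methylbut-2-en-1-yl on this aromatic carbon, ortho to two hydroxy groups, gives an at least 3.1-fold lower number from compound 3 to compound 4 (0.49 log units; beyond the scatter). This shows that the core with one 3-methylbut-2-en-1-yl group reaches a measured number, whereas the core with a second such group on this carbon does not. Going by these compounds, the full size of the step stays unknown, as the value of compound 3 is only a limit: the limit of > 100000 nM in this assay, at which 2 of the 4 values shown sit.

The compounds shown leave open whether an amine or a carboxylic acid on this carbon would change the number.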